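A few compounds are considered here, and "the series" means these few. Any claim that something is new, unique, unknown or untested is made for them only; others in the source may bear on it.

In an in vitro functional assay on HEK285-7 cells for antagonist activity at prostaglandin D2 receptor 2 (Homo sapiens), read by BRET and beta-arrestin recruitment (on this read-out lower numbers stand for smaller maximal responses and higher numbers for larger maximal responses), the measured compounds gave:

compound 1 `CCC(c1ccccc1)c1nc(-c2ccc(Cl)cc2)c(CC(=O)O)s1`: 50%
compound 2 `O=C(O)Cc1sc(C(c2ccccc2)c2ccccc2)nc1-c1ccc(C(F)(F)F)cc1`: 80%
compound 3 `O=C(O)Cc1sc(C(c2ccc(F)cc2)c2ccc(F)cc2)nc1-c1ccncc1`: 80%

Compound 1 stands lowest of the three. Compound 2 and compound 3 each reach a larger maximal response, and the gap to either lies beyond the usual scatter; between those two there is no difference worth the name.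

Compound 4 `O=C(O)Cc1sc(C(c2ccccc2)c2ccccn2)nc1-c1ccc(Cl)cc1` is the next compound to be measured in this assay. It differs from compound 1 in one place: pyridin-2-yl in place of ethyl on a saturated chain carbon bound to two aromatic carbons. With this change the saturated chain carbon carries two aromatic rings, as it does in compound 2 and in compound 3, the two compounds with the larger responses. The step is therefore expected to be upward and beyond the scatter, about a number 20 percentage points higher from compound 1 to compound 4 (beyond the scatter). Compound 4 is estimated at 70%, between 50% and 90%.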

Compound 4, largest response reached (reported as efficacy), in percent of the reference or control that the assay uses: 55%
Compound 4: middle estimate off by 15 percentage points, on the high side, and the stated range covers the measured number.
By their numbers in this assay, from the lowest: compounds 1 and 4 (each within the scatter of the next); then compounds 2 and 3 (each within the scatter of the next).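

Pyridin-2-yl in place of ethyl on a saturated chain carbon bound to two aromatic carbons gives a number 5 percentage points higher from compound 1 to compound 4 (within the scatter) in this assay. In this pair, then, a second aromatic ring on that carbon does not set compound 4 apart from compound 1. Nothing at hand gives a reason for this result. The compounds shown leave open whether pyridin-3-yl or a propyl chain at this position would give a different maximal response with the rest of compound 1 kept. They also leave open how a methyl group there would compare.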